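Swapping a Sulfonamide Ring Cap: Two Sulfonamide Series Compared

The source may report more compounds than this note shows. Statements on the series, on what has been measured and on what is new or still open speak of the compounds shown alone.

Measured compounds:
- compound 1, `Cc1cc(NS(=O)(=O)c2ccc(NCc3coc4ccccc4c3=O)cc2)no1`: 59700 nM
- compound 2, `O=c1c(CNc2ccc(S(=O)(=O)Nc3ncccn3)cc2)coc2ccccc12`: 85300 nM
- compound 3, `CCOC1Oc2ccccc2C(=O)/C1=C/Nc1ccc(S(=O)(=O)Nc2cc(C)on2)cc1`: 57200 nM

All three were tested in a functional assay on A549 cells (Homo sapiens) for cytotoxicity, read by sulforhodamine B assay, with a stated time of 72 h; a higher number here means a weaker inhibitor, a lower number a stronger inhibitor. Compound 1 and compound 2 share a core, and the difference between them is pyrimidin-2-yl in place of 5-methyl-1,2-oxazol-3-yl on a sulfonamide nitrogen. That change gave a 1.4-fold higher number from compound 1 to compound 2 (0.15 log units; within the scatter). Compound 3 has a different core from compound 1; how the two cores differ is not broken down here, and the two values alone show that they sit close together, within the usual scatter.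

Compound 4, `CCOC1Oc2ccccc2C(=O)/C1=C/Nc1ccc(S(=O)(=O)Nc2ncccn2)cc1`, has not yet been measured. It relates to compound 3 as compound 2 relates to compound 1: the difference is pyrimidin-2-yl in place of 5-methyl-1,2-oxazol-3-yl on a sulfonamide nitrogen, the same change made at the same place. Since the first occurrence of this change, seen in a 1.4-fold higher number from compound 1 to compound 2 (0.15 log units; within the scatter), stayed within the scatter, a step of similar size is expected here, that is a 1.4-fold higher number from compound 3 to compound 4 (0.15 log units; within the scatter) in this assay. Compound 4 is therefore expected to give about 80000 nM in this assay, with a plausible range from 40000 nM to 160000 nM, remaining a weak inhibitor like the three measured compounds.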

Compound 4, half-maximal inhibitory concentration: > 100000 nM
Compound 4 was reported as a limit (the forecaster's own chance of this, stated with the estimate: 25%); middle value at least 1.2-fold (0.09 log units) from the limit.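

In this assay compound 4 gives > 100000 nM, which is a limit of the assay and not a number. Placing pyrimidin-2-yl where 5-methyl-1,2-oxazol-3-yl stood on the sulfonamide nitrogen therefore gives only a floor for the step, an at least 1.7-fold higher number from compound 3 to compound 4 (0.24 log units; that floor lies within the scatter), and its true size stays unknown, so the two occurrences of this change can be compared only in part: the same change on two cores in this assay, a 1.4-fold higher number (0.15 log units; within the scatter) from compound 1 to compound 2 and an at least 1.7-fold higher number (0.24 log units; that floor lies within the scatter) from compound 3 to compound 4; the limit leaves it open whether they differ. Nothing here speaks against the change carrying over from one core to the other, but this does not show that it has the same size on both cores, and the limit hides how far the value of compound 4 really lies.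

The compounds shown carry only these two ring groups on the sulfonamide nitrogen, so how a phenyl ring or a simple methyl group there would read on either core remains open. Whether the change behaves the same way outside this assay is also left open.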